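Swapping vinyl for pent-1-en-1-yl on a carbonyl carbon

The source may hold more compounds than are shown below. What is called first, only, known or untested is meant among the compounds shown, and "the series" means these compounds.

In a functional assay on A549 cells (Homo sapiens) for inhibition, read by MTT assay, with a stated time of 72 h (on this read-out higher numbers stand for weaker inhibition and lower numbers for stronger inhibition), compound 1 `C=CC(=O)Nc1cc(Nc2nc3c(c(-c4cn(C)c5ccc(F)cc45)n2)CSCC3)c(OC)cc1N(C)CCN(C)C` gives 4550 nM and compound 2 `C=CC(=O)Nc1cc(Nc2nc3c(c(-c4cn(C)c5ccccc45)n2)CS(=O)(=O)CC3)c(OC)cc1N(C)CCN(C)C` gives 8690 nM as its result. In this assay compound 3 `C=CC(=O)Nc1cc(Nc2nc3c(c(-c4cn(C)c5ccc(F)cc45)n2)CS(=O)(=O)CC3)c(OC)cc1N(C)CCN(C)C` gives 4640 nM and so sits within the usual scatter of both of the other two compounds.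

The next molecule is compound 4 `CCC/C=C\C(=O)Nc1cc(Nc2nc3c(c(-c4cn(C)c5ccc(F)cc45)n2)CS(=O)(=O)CC3)c(OC)cc1N(C)CCN(C)C` which departs from compound 3 in a single place. The difference is pent-1-en-1-yl in place of vinyl on a carbonyl carbon and in words it means pent-1-en-1-yl in place of vinyl on a carbonyl carbon.

Going by the values given here, only one measured step involves a single change, and it is a 1.9-fold lower number from compound 2 to compound 3 (0.27 log units; within the scatter) for fluoro in place of hydrogen on an aromatic carbon. That is a different kind of change, so it offers only a weak guide. Among the compounds with values here, no measured compound alters the group on the carbonyl carbon, which leaves the size of this new step largely open. The expectation is therefore a small move towards a higher number, with a step beyond the scatter still possible in either direction. The expected change is a 1.3-fold higher number from compound 3 to compound 4 (0.11 log units; within the scatter) and it remains a cautious estimate. For compound 4 the estimated value is 6000 nM with an expected range from 2500 nM to 15000 nM in this wide window.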

Compound 4, half-maximal inhibitory concentration: 7570 nM
Estimate against measurement, compound 4: 1.3-fold (0.10 log units) below, and the stated range covers the measured number.
By their numbers in this assay, from the lowest: compounds 1, 3, 4 and 2 (each within the scatter of the next).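

Going by these compounds alone, this is the only measured change on the carbonyl carbon whose other neighbour is the amide-type nitrogen, and in this assay replacing vinyl with pent-1-en-1-yl gives a 1.6-fold higher number from compound 3 to compound 4 (0.21 log units; within the scatter). The entering group has 5 heavy atoms where the leaving group has 2, yet the read-out of this one pair stays within the usual scatter, so this assay does not separate the two compounds, and this single step gives no sign that the larger group matters here. No measurement shown explains this result or says what either group does in the cells.

From the compounds shown here alone, compound 1 and compound 2 both carry vinyl, so it remains open whether the same swap would also stay within the scatter on their slightly different structures. Also open, going by these compounds, is how this position would respond to other groups on the carbonyl carbon, such as a dimethylamino group at the end of the chain, a longer chain, or a saturated propyl group with no double bond.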